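The source may report more compounds than this note shows. Statements on the series, on what has been measured and on what is new or still open speak of the compounds shown alone.

The measured compounds so far:

Compound 1 `COc1cc(C(N)=O)cc2nc(NC(=O)c3ccccn3)n(CCCNC(=O)OCc3ccccc3)c12`; in an assay for activation of interferon regulatory factor 3 (Homo sapiens), read by a luciferase reporter, with a stated time of 20 h (a lower number here means that less compound is needed, a higher number that more compound is needed for the effect), compound 1 gives > 100000 nM, a limit of the assay rather than a number.
Compound 2 `COc1cc(C(N)=O)cc2nc(NC(=O)c3cccn3C)n(CCCNC(=O)OCc3ccccc3)c12`; in this assay compound 2 gives > 100000 nM, again a limit of the assay.

Within the data shown here, compound 2 therefore stands nowhere that can be placed on a scale: only a limit is known for it, and the one other value shown is a limit too, so that (the limit of > 100000 nM in this assay, at which 2 of the 2 values shown sit). Among the measured compounds shown here, the single step between measured compounds, a step that the two limits leave unreadable from compound 1 to compound 2, is consequently of unreadable size, since both of its ends are limits.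

The next compound, compound 3 `COc1cc(C(N)=O)cc2nc(NC(=O)C3CCCN3C)n(CCCNC(=O)OCc3ccccc3)c12`, is reached from compound 2 by a change at the same position that was varied before: 1-methylpyrrolidin-2-yl in place of 1-methyl-1H-pyrrol-2-yl on a carbonyl carbon. For the measured compounds named here, the only measured step that bears on this position is a step that the two limits leave unreadable from compound 1 to compound 2, and it gives no readable size or direction. With no readable step on record and both known values sitting at the limit, the estimate for compound 3 is that it stays there as well: 100000 nM, expected within 20000 nM to 400000 nM, meaning an expected step of a number no higher from compound 2 to compound 3 (the limit leaves the size open).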

Compound 3, half-maximal effective concentration: > 100000 nM
Compound 3: only a limit was reported; the forecaster's own chance of this, stated with the estimate: 85%; the middle value lies on the limit itself.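

In this assay compound 3 gives > 100000 nM, again a limit of the assay and not a number. The steps from compound 1 and compound 2 to compound 3 therefore cannot be read: the limit of > 100000 nM in this assay, at which 3 of the 3 values shown sit.

The compounds shown leave open whether the groups on the carbonyl carbon differ in effect at all.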